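A few compounds are considered here, and "the series" means these few. Any claim that something is new, unique, unknown or untested is made for them only; others in the source may bear on it.

Compound 1 `CC1=C(C(=O)CC(C)C)C(c2ccsc2)NC(=O)N1` gives 37% in an assay on membranes from CHO cells for displacement of a labelled ligand from adenosine receptor A1 (Homo sapiens), read by scintillation counting, with a stated time of 60 min, tested at 1 uM; a higher number here means more inhibition at the concentration tested (going by the name of the read-out), a lower number less inhibition.
Compound 2 `CC1=C(C(=O)SC(C)C)C(c2ccsc2)NC(=O)N1` gives 24% in this assay.
Compound 3 `CC1=C(C(=O)OC2CCCCC2)C(c2ccco2)NC(=O)N1` gives 1% in this assay.

Of the three measured compounds, compound 3 stands lowest in this assay: compound 2 lies a step above it, and compound 1 lies further above it still, both beyond the scatter. For the measured compounds named here, the one measured step, a number 13 percentage points lower from compound 1 to compound 2 (beyond the scatter), concerns the group on the carbonyl carbon and says nothing directly about the aromatic ring on the saturated ring carbon.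

Compound 4 `CC1=C(C(=O)OC2CCCCC2)C(c2ccsc2)NC(=O)N1` differs from compound 3 by thiophen-3-yl in place of furan-2-yl on a saturated ring carbon. Going by the values given here, no measured pair isolates this exchange. Compounds 1 and 2, which carry thiophen-3-yl, sit well above compound 3, but they also differ from compound 3 on the carbonyl carbon, so the two changes cannot be separated. Among the compounds with values here, the data give no step for the ring exchange alone, and the expected direction therefore rests on the weak hint that both thiophen-3-yl compounds score higher than compound 3.

Compound 4 is expected to rise from compound 3 by a number 13 percentage points higher from compound 3 to compound 4 (beyond the scatter), a modest step at best. The estimate for compound 4 in this assay is 14%, with a range from 0% to 34%.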

Compound 4, a percentage reported as inhibition, at one concentration (the size of the read-out at that concentration, not a potency): 8%
For compound 4 the middle estimate is 6 percentage points above the measured one, within the range that was stated.
By their numbers in this assay, from the lowest: compounds 3 and 4 (each within the scatter of the next); then compound 2; then compound 1.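

In this assay, for the compounds shown here, the exchange of furan-2-yl for thiophen-3-yl on the saturated ring carbon, with cyclohexyloxy held on the carbonyl carbon, gives a number 7 percentage points higher from compound 3 to compound 4 (within the scatter) and so separates this position from the carbonyl carbon, which the earlier compounds could not do. With thiophen-3-yl held in place, cyclohexyloxy in place of isopropylsulfanyl gives a number 16 percentage points lower from compound 2 to compound 4 (beyond the scatter) and cyclohexyloxy in place of isobutyl gives a number 29 percentage points lower from compound 1 to compound 4 (beyond the scatter) on the same carbonyl carbon. Among these four compounds, every step beyond the scatter therefore lies on the carbonyl carbon, while the single step at the saturated ring carbon does not go beyond it.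

Going by these compounds, it remains open whether the ring exchange would read the same with isobutyl or isopropylsulfanyl on the carbonyl carbon, and whether a phenyl ring at the saturated ring carbon or an amine on the carbonyl carbon would move the number at all. Why the groups on the carbonyl carbon separate as they do also stays open, as no supporting measurement bears on it.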